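What one hydroxy group less may change

The compounds below may be only part of what the source reports. "The series", "measured", "known", "first", "only" and "open" are said of these compounds alone.

- Compound 1 `CSc1nc2n(n1)C(c1ccc(O)cc1O)C([N+](=O)[O-])=NN2` gives 201000 nM
- Compound 2 `O=[N+]([O-])C1=NNc2ncnn2C1c1ccc(O)c(O)c1O` gives 228000 nM

Both values come from an ADME assay on MDCK cells (Canis lupus familiaris) for cytotoxicity; a higher number here means that more compound is tolerated, a lower number that less compound is tolerated. Within the data shown here, compound 2 holds the higher of only two numbers, but its gap to compound 1 lies within the scatter, so the two cannot be told apart. Compound 3 `O=[N+]([O-])C1=NNc2ncnn2C1c1ccc(O)cc1O` has not been measured. It differs from compound 2 in one place, with hydrogen in place of hydroxy on an aromatic carbon. Among the measured compounds shown here, no measured pair shows what this change does, so the expectation rests only on the two close values. No shift beyond the scatter is expected in this assay, and the estimated change a 1.1-fold lower number from compound 2 to compound 3 (0.04 log units; within the scatter) is small. The expected value for compound 3 is 210000 nM, with an estimated range from 110000 nM to 400000 nM.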

Compound 3, half-maximal cytotoxic concentration: 90000 nM
The estimate for compound 3 lay 2.3-fold (0.37 log units) above the measured number; the whole stated range lies above it.
By their numbers in this assay, from the lowest: compound 3; then compounds 1 and 2 (each within the scatter of the next).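

Hydroxy on this aromatic carbon, ortho to two hydroxy groups, turns out to matter in this assay: hydrogen in its place gives a 2.5-fold lower number from compound 2 to compound 3 (0.40 log units; beyond the scatter) and so less compound is tolerated. The earlier pair could not show this, since compounds 1 and 2 differ in more than one place and their values lie within the scatter. Hydrogen in place of methylsulfanyl on an aromatic carbon points the same way, with a 2.2-fold lower number from compound 1 to compound 3 (0.35 log units; beyond the scatter) as the step, and nothing available explains either step.

On these data alone, whether methoxy or an amine on the hydroxy-bearing carbon would match hydroxy or hydrogen remains open. So does the outcome of a longer chain, such as ethylsulfanyl, in place of methylsulfanyl.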